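Hydroxy in Place of Chloro: Expecting Compound 4

The compounds below may be only part of what the source reports. "The series", "measured", "known", "first", "only" and "open" are said of these compounds alone.

Three compounds have been measured in a functional assay on the whole organism for inhibition, with Rattus norvegicus as the target, read by paw edema, with stated times of 1 h and 6 h, at a dose of 0.03 mg/kg by the oral route; a lower number here means less inhibition, a higher number more inhibition at the dose given (going by the name of the read-out):
Compound 1 `CC1=NN(C(=O)c2cc3ccccc3oc2=O)C(=O)C1CNc1ccccn1` gives 50.3%.
Compound 2 `CC1=NN(C(=O)c2cc3ccccc3oc2=O)C(=O)C1CNc1c(O)cc(S(=O)(=O)O)c2ccccc12` gives 45.3%.
Compound 3 `CC1=NN(C(=O)c2cc3ccccc3oc2=O)C(=O)C1CNc1ccc(Cl)cc1` gives 71.5%.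

Compound 3 stands highest of the three, beyond the scatter from both compound 1 and compound 2. Among the measured compounds shown here, the only single-point step measured is a number 21.2 percentage points higher from compound 1 to compound 3 (beyond the scatter), so the group on the amine nitrogen does move the number. Compound 4 `CC1=NN(C(=O)c2cc3ccccc3oc2=O)C(=O)C1CNc1ccc(O)cc1` keeps that arrangement but carries hydroxy in place of chloro on an aromatic carbon. For the measured compounds named here, no measured step matches this exact change. Compound 2 also bears a hydroxy group, though on a different ring with further groups, and gives the lowest value. Taken together, the hydroxy is expected to give back part of the gain seen in compound 3, so compound 4 is estimated at 55%, between 40% and 70%, a step of a number 16.5 percentage points lower from compound 3 to compound 4 (beyond the scatter).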

Compound 4, a percentage reported as inhibition, in the whole organism at one dose (the size of the read-out at that dose, not a potency): 50.7%
Compound 4: middle estimate off by 4.3 percentage points, on the high side; the measured number falls inside the stated range.
By their numbers in this assay, from the lowest: compounds 2, 1 and 4 (each within the scatter of the next); then compound 3.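

Putting hydroxy in place of chloro on this aromatic carbon gives a direct test of the position, and the number changes: there is a number 20.8 percentage points lower from compound 3 to compound 4 (beyond the scatter), a drop beyond the scatter. The 4-hydroxyphenyl group, by contrast, does not separate from pyridin-2-yl, with a number 0.4 percentage points higher from compound 1 to compound 4 (within the scatter), so among these compounds the higher number goes with 4-chlorophenyl and not with a benzene ring alone. No measurement here explains this difference.

Going by these compounds, whether fluoro, methoxy or an amine at this place would give a number nearer compound 3 or compound 4 remains open.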